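The source may report more compounds than this note shows. Statements on the series, on what has been measured and on what is new or still open speak of the compounds shown alone.

Measured compounds in a functional assay on KB cells (Homo sapiens) for cytotoxicity; on this read-out higher numbers stand for weaker inhibition and lower numbers for stronger inhibition:
compound 1 `CC(C)(C)c1ccc(Cn2cc(C(N)=O)c3c(N)ncnc32)cc1` gives 900 nM;
compound 2 `CC(C)(C)c1ccc(Cn2cc(C(=N)S)c3c(N)ncnc32)cc1` gives 7000 nM;
compound 3 `COc1ccc(Cn2cc(C(N)=O)c3c(N)ncnc32)cc1` gives 47000 nM.

Compound 3 has the highest number of the three; its nearest neighbour is compound 2 and its furthest is compound 1, and both gaps lie beyond the scatter. The unmeasured compound 4 `COc1ccc(Cn2cc(C(=N)S)c3c(N)ncnc32)cc1` differs from compound 3 by one change: a group of 3 heavy atoms (1 carbon, 1 nitrogen, 1 sulfur; no ring) in place of a group of 3 heavy atoms (1 carbon, 1 nitrogen, 1 oxygen; no ring), on an aromatic carbon. Going by the values given here, the single measured step that bears on this change is a 7.8-fold higher number from compound 1 to compound 2 (0.89 log units; beyond the scatter), a modest move to a higher number. Carrying that over, a step of a 6.4-fold higher number from compound 3 to compound 4 (0.81 log units; beyond the scatter) is expected in this assay, towards a higher number. Compound 4 is therefore estimated at 300000 nM, with a range of 80000 nM to 1200000 nM.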

Compound 4, half-maximal inhibitory concentration: 28000 nM
Compound 4: middle estimate off by 11-fold (1.03 log units), on the high side; measured number outside the range, below it.
By their numbers in this assay, from the lowest: compound 1; then compound 2; then compounds 4 and 3 (each within the scatter of the next).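

In this assay, placing the sulfur-bearing group on this aromatic carbon of the five-membered ring, in place of carbamoyl, gives a 1.7-fold lower number from compound 3 to compound 4 (0.22 log units; within the scatter) when methoxy is present. The effect of this change therefore depends on the other substituent and does not carry over between the two cores: the same change on two cores in this assay, a 7.8-fold higher number (0.89 log units; beyond the scatter) from compound 1 to compound 2 and a 1.7-fold lower number (0.22 log units; within the scatter) from compound 3 to compound 4, 13-fold (1.12 log units) apart, beyond the scatter of two such steps Methoxy in place of tert-butyl still gives a 4.0-fold higher number from compound 2 to compound 4 (0.60 log units; beyond the scatter), so that step also depends on the group at this position: the same change on two cores in this assay, a 52-fold higher number (1.72 log units; beyond the scatter) from compound 1 to compound 3 and a 4.0-fold higher number (0.60 log units; beyond the scatter) from compound 2 to compound 4, 13-fold (1.12 log units) apart, beyond the scatter of two such steps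

Going by these compounds, whether a nitrile or a carboxylic acid here would follow carbamoyl or the sulfur-bearing group remains open. So does how either would behave with an ethyl group or chlorine in place of methoxy or tert-butyl.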